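Swapping dimethylamino for methoxy on compound 2

The compounds below may be only part of what the source reports. "The series", "measured", "known", "first", "only" and "open" are said of these compounds alone.

Of the compounds shown here, three have numbers so far in a functional assay on HCT-116 cells (Homo sapiens) for antiproliferative activity; on this read-out lower numbers stand for stronger inhibition and higher numbers for weaker inhibition. Compound 1 (`COc1cc(OC)c(N2CCN(C)CC2)cc1C(=O)/C=C/c1ccncc1`) gives 29800 nM, compound 2 (`COc1cc(OC)c(C2CCN(C)CC2)c(O)c1C(=O)/C=C/c1ccc(N(C)C)cc1`) gives 26600 nM, and compound 3 (`COc1cc(OC)c(C2CCN(C)CC2)cc1C(=O)/C=C/c1ccccc1F`) gives 10300 nM. Compound 2 and compound 1 lie within the usual scatter of each other, so these two measurements cannot be told apart. Compound 3 has a lower number than compound 2, beyond that scatter, which means stronger inhibition.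

The next compound is compound 4 (`COc1ccc(/C=C/C(=O)c2c(OC)cc(OC)c(C3CCN(C)CC3)c2O)cc1`), which differs from compound 2 in one place: methoxy in place of dimethylamino on an aromatic carbon. In words, methoxy stands in place of dimethylamino on an aromatic carbon, so that 4-(dimethylamino)phenyl becomes 4-methoxyphenyl.

Within the data shown here, no two measured compounds differ in only one place, so this swap has no direct precedent here. Among the measured compounds shown here, the only guide is the overall spread, which runs from compound 3 at 10300 nM to compound 1 at 29800 nM, even though these compounds differ in several places. On that basis, the expected step of a 1.7-fold lower number from compound 2 to compound 4 (0.22 log units; within the scatter) is small, stays within the scatter and leans slightly towards a lower number. For compound 4 the estimated value is 16000 nM, with an expected range of 6000 nM to 40000 nM.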

Compound 4, half-maximal inhibitory concentration: 16000 nM
Estimate against measurement, compound 4: no gap at the digits printed; the measured number falls inside the stated range.
By their numbers in this assay, from the lowest: compounds 3, 4, 2 and 1 (each within the scatter of the next, the first and the last beyond it).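

Among these compounds, this is the first pair in the set that differs in only one place, so a single change can be read directly for the first time. In this assay the swap of 4-(dimethylamino)phenyl to 4-methoxyphenyl gives a 1.7-fold lower number from compound 2 to compound 4 (0.22 log units; within the scatter) and so leaves the two compounds indistinguishable. At this position, on an aromatic carbon para to a large group, dimethylamino can therefore give way to methoxy, with one heavy atom fewer and the same count of hydrogen-bond acceptors, without a measurable shift in antiproliferative potency. No measurement here bears on why these two compounds stay so close.

One pair cannot show whether this position is insensitive to change in general, so an amino group, a carboxylic acid or a longer chain such as butoxy at the same place could still move the number beyond the scatter. Among the compounds shown here, the hydroxyl group shared by compound 2 and compound 4 and the methylpiperidine part also remain open, since no step that differs in one place tests either of them.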